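Replacing a methoxy group with tert-butyl on the phenoxy ring

The source may hold more compounds than are shown below. What is called first, only, known or untested is meant among the compounds shown, and "the series" means these compounds.

Three compounds share a core and differ only in the group attached to it. Compound 1 `COc1cccc(CNCCCNc2ccnc3cc(Cc4cc(C)cc(C)c4)ccc23)c1O` carries a 3,5-dimethylbenzyl group there and, in an ADME assay on HepG2 cells (Homo sapiens) for cytotoxicity, read by luminescence, CellTiter-Glo and ATP content, with a stated time of 72 h (a lower number here means that less compound is needed, a higher number that more compound is needed for the effect), compound 1 gives 2680 nM. Compound 2 `COc1cccc(Oc2ccc3c(NCCCNCc4cccc(OC)c4O)ccnc3c2)c1` carries 3-methoxyphenoxy instead, and in this assay compound 2 gives 5300 nM, a step of a 2.0-fold higher number from compound 1 to compound 2 (0.30 log units; within the scatter). Among the compounds with values here, compound 3 `COc1ccc(Oc2ccc3c(NCCCNCc4cccc(OC)c4O)ccnc3c2)cc1` carries 4-methoxyphenoxy; in this assay compound 3 gives 5500 nM, which is the highest of the three numbers, although the step of a 1.0-fold higher number from compound 2 to compound 3 (0.02 log units; within the scatter) is within the scatter and only the step of a 2.1-fold higher number from compound 1 to compound 3 (0.31 log units; beyond the scatter) is beyond it.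

Compound 4 `COc1cccc(CNCCCNc2ccnc3cc(Oc4ccc(C(C)(C)C)cc4)ccc23)c1O` is not yet measured. Its difference from compound 3 is tert-butyl in place of methoxy on an aromatic carbon. Within the data shown here, no measured step tests this exact exchange. The nearest guide is the step of a 1.0-fold higher number from compound 2 to compound 3 (0.02 log units; within the scatter), which moved a methoxy group around the same phenoxy ring without effect beyond the scatter, so only a small step is expected, with direction uncertain. The expected step is a 1.4-fold lower number from compound 3 to compound 4 (0.14 log units; within the scatter). Compound 4 is therefore estimated at 4000 nM, within a range from 1500 nM to 11000 nM.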

Compound 4, half-maximal effective concentration: 1500 nM
Compound 4: middle estimate off by 2.7-fold (0.43 log units), on the high side; low and high end bracket the measured number.
By their numbers in this assay, from the lowest: compounds 4, 1, 2 and 3 (each within the scatter of the next, the first and the last beyond it).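

The two methoxyphenoxy compounds gave no sign that the group on this ring mattered, yet in this assay tert-butyl in place of methoxy gives a 3.7-fold lower number from compound 3 to compound 4 (0.56 log units; beyond the scatter). The comparison with the other methoxy compound agrees, at a 3.5-fold lower number from compound 2 to compound 4 (0.55 log units; beyond the scatter), so what sits on this ring can shift the number even though moving the methoxy group did not. Set against the 3,5-dimethylbenzyl group, the 4-(tert-butyl)phenoxy group gives a 1.8-fold lower number from compound 1 to compound 4 (0.25 log units; within the scatter), so these two compounds cannot be told apart here.

Nothing measured here explains why the exchange of methoxy for tert-butyl shifts the number. From the compounds shown here alone, it also remains open whether another group on the same aromatic carbon, such as an amine or a carboxylic acid, would shift the number as far or in the opposite direction.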